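From dimethylamino to methoxy: a working estimate

The compounds below may be only part of what the source reports. "The series", "measured", "known", "first", "only" and "open" are said of these compounds alone.

In a functional assay on DU-145 cells (Homo sapiens) for inhibition, read by trypan blue exclusion, with a stated time of 96 h (a lower number here means a stronger inhibitor of growth, a higher number a weaker inhibitor of growth), compound 1 (`COc1ccc(/C=C(/Sc2ccc(Br)cc2)C(=O)c2ccc(Br)cc2)cc1`) gives 25000 nM. Compound 2 (`CN(C)c1ccc(/C=C(/Sc2ccc(Br)cc2)C(=O)c2ccc(Cl)cc2)cc1`) gives > 100000 nM, which is a limit of the assay and not a number. Of the two measured compounds, only compound 2 stands at this limit, so it offers no exact starting point for a step.

Compound 3 (`COc1ccc(/C=C(/Sc2ccc(Br)cc2)C(=O)c2ccc(Cl)cc2)cc1`) differs from compound 2 in one place: methoxy in place of dimethylamino on an aromatic carbon. This puts methoxy in place of dimethylamino on an aromatic carbon, para to a large group.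

Among the compounds with values here, no measured pair shows the size of this change directly. Within the data shown here, compound 1 also carries methoxy and gives 25000 nM, the only number available to support the expectation. A move toward stronger growth inhibition in this assay is therefore expected, beyond the scatter, with the expected step being an at least 3.3-fold lower number from compound 2 to compound 3 (0.52 log units; beyond the scatter). That step remains uncertain, and a further reading at the limit cannot be ruled out. For compound 3 the estimated value is 30000 nM, with an expected range of 10000 nM to 90000 nM.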

Compound 3, concentration for 50% growth inhibition: 50000 nM
For compound 3 the middle estimate is 1.7-fold (0.22 log units) below the measured one; measured number inside the range.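

In this assay, within the data shown here, methoxy in place of dimethylamino on an aromatic carbon, para to a large group, gives an at least 2.0-fold lower number from compound 2 to compound 3 (0.30 log units; that floor lies within the scatter), the first direct reading of this change, and it places compound 3 on the measurable part of the scale at 50000 nM. Compound 2 remains a limit of the assay, > 100000 nM, and not a number, so the true size of the step stays unfixed and only its floor can be stated: the limit of > 100000 nM in this assay, at which 1 of the 3 values shown sits. Chloro in place of bromo on an aromatic carbon gives a 2.0-fold higher number from compound 1 to compound 3 (0.30 log units; within the scatter), so this exchange does not separate the two values, and the methoxy compounds read as one level whichever of the two halogens they carry.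

The compounds shown leave open how other groups in this place, such as hydroxy, a primary amine or a longer alkoxy chain, would read against methoxy. They also leave open whether any change at this position can bring the series well below the level of the two methoxy compounds, and how dimethylamino reads with bromo in place of chloro.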